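A few compounds are considered here, and "the series" means these few. Any claim that something is new, unique, unknown or untested is made for them only; others in the source may bear on it.

Compound 1, `COc1ccccc1/C=C/C(=O)OC/C=C/c1cc(OC)c(OC)cc1OC`: 100%
Compound 2, `COc1cc(OC)c(OC)cc1/C=C/COC(=O)/C=C/c1ccc(OC)c(OC)c1`: 100%
Compound 3, `COc1cc(OC)c(OC)cc1/C=C/COC(=O)/C=C/c1ccc(F)cc1`: 100%

All three were tested in a functional assay on the whole organism (strain Kunming) with Mus musculus as the target, with a stated time of 0.5 h, at a dose of 100 mg/kg by the intraperitoneal route; on this read-out lower numbers stand for a stronger effect and higher numbers for a weaker effect at the one dose given. On these numbers compound 2 stands level with the other two at the digits shown: the step of no change at the digits printed from compound 1 to compound 2 (within the scatter) lies within the scatter, the step of no change at the digits printed from compound 2 to compound 3 (within the scatter) likewise, and the step of no change at the digits printed from compound 1 to compound 3 (within the scatter) as well. The three compounds share one core and differ only in the aryl group on a double-bonded chain carbon bound to a double-bonded chain carbon, and none of the three exchanges of that group moved the read-out beyond the scatter.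

Compound 4, `COc1cc(OC)c(OC)cc1/C=C/COC(=O)/C=C/c1ccc(Cl)cc1`, has not yet been measured. It differs from compound 2 in one place: 4-chlorophenyl in place of 3,4-dimethoxyphenyl on a double-bonded chain carbon bound to a double-bonded chain carbon. The three measured steps bear directly on this change, since each of them also exchanges the aryl group at the same place, and each was within the scatter. From that, the expected step of no change at the digits printed from compound 2 to compound 4 (within the scatter) is none beyond the scatter, in no particular direction. Compound 4 is therefore estimated to give 100% in this assay, with a range from 88% to 100%. Among the compounds with values here, only three aryl groups have been tried, so this expectation rests on a small base.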

Compound 4, a percentage reported as activity, at one dose (the size of the read-out at that dose, not a potency): 100%
For compound 4 middle estimate and measured number coincide at the digits printed; the range from low to high includes it.
By their numbers in this assay, from the lowest: compounds 1, 2, 3 and 4 (each within the scatter of the next).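

In this assay, the exchange of one halogen for another on an aromatic carbon can now be read directly: chloro in place of fluoro gives no change at the digits printed from compound 3 to compound 4 (within the scatter). The 4-chlorophenyl group also fits the earlier picture when set against the two methoxy-bearing aryl groups, with no change at the digits printed from compound 2 to compound 4 (within the scatter) and no change at the digits printed from compound 1 to compound 4 (within the scatter), so four different aryl groups on a double-bonded chain carbon bound to a double-bonded chain carbon now give the same reading, and a chlorine atom at this place has not separated compound 4 from the others. No supporting measurement is available that would explain this sameness.

Going by these compounds, all four compounds keep the shared core and carry neutral aryl groups at this place, so it remains open whether a carboxylic acid or an amine on that aromatic ring, or a plain alkyl chain in place of the aryl group, would give a different reading. On these data alone, with a single dose and a single time, it also remains open whether these compounds would separate under other conditions, or whether changes elsewhere on the shared core would move the number.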